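A few compounds are considered here, and "the series" means these few. Any claim that something is new, unique, unknown or untested is made for them only; others in the source may bear on it.

Compounds measured so far:
- compound 1, `CC(C)n1cnc2c(Nc3cccc(-c4ncccn4)c3)nc(Cl)nc21`: 10000 nM
- compound 2, `CC(C)n1cnc2c(Nc3cccc(-c4cncnc4)c3)nc(Cl)nc21`: "not determined" (no result reported)
- compound 3, `CCC[C@@H](O)Nc1nc(Nc2ccc(-c3ncccn3)cc2)c2ncn(C(C)C)c2n1`: 180 nM

In an assay on isolated protein (Asteroidea) for inhibition of G2/mitotic-specific cyclin-B (Asterina pectinifera), read by scintillation counting and 33P incorporation, with a stated time of 30 min (on this read-out lower numbers stand for stronger inhibition and higher numbers for weaker inhibition), compound 3 gives 180 nM, the lowest of the two numbers in hand; compound 1 stands far higher, beyond the scatter, and compound 2 has no number. Compound 4, `CCC[C@H](O)Nc1nc(Nc2ccc(-c3ncccn3)cc2)c2ncn(C(C)C)c2n1`, is the mirror image at one point: the two compounds have the same atoms and bonds and differ only in configuration as drawn: 1 of 1 stereo elements differ; a stereocentre at a saturated chain carbon is drawn R in compound 3 and S in compound 4. Among the measured compounds shown here, no pair of measured compounds differs by this kind of change alone, so its size is uncertain; such a change can leave the number unmoved or shift it either way. For compound 4 a moderate rise is expected, a 2.2-fold higher number from compound 3 to compound 4 (0.35 log units; beyond the scatter), with wide uncertainty. The estimate for compound 4 in this assay is 400 nM, within 80 nM to 2500 nM.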

Compound 4, half-maximal inhibitory concentration: 500 nM
For compound 4 the middle estimate is 1.3-fold (0.10 log units) below the measured one; the measured number falls inside the stated range.
By their numbers in this assay, from the lowest: compound 3; then compound 4; then compound 1.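

In this assay, the stereocentre at the saturated chain carbon gives the first single-change comparison, with a 2.8-fold higher number from compound 3 to compound 4 (0.44 log units; beyond the scatter). The shift can be assigned to this stereocentre alone: the fact that compounds 3 and 4 differ only in the configuration as drawn. The step is modest, so inverting this centre changes the number without abolishing inhibition.

As far as these compounds go, whether a longer chain on this carbon, or an amine in place of its hydroxyl, would widen or narrow the gap between the two configurations remains open. From the compounds shown here alone, it is also open whether the R form would keep its lower number with other groups on the shared core.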